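The source may report more compounds than this note shows. Statements on the series, on what has been measured and on what is new or still open speak of the compounds shown alone.

Among the measured compounds shown here, in a toxicity assay on Huh-7.5 cells (Homo sapiens) for inhibition, read by MTT assay, with a stated time of 96 h (a lower number here means that less compound is tolerated, a higher number that more compound is tolerated), compound 1 (`CCC(=O)Nc1cc(C(=O)Nc2ccc(OC)cc2)ccc1OC(C)C`) gives 113000 nM and compound 2 (`CCOc1ccc(C(=O)Nc2ccc(OC)cc2)cc1NC(=O)CC`) gives 73200 nM, so compound 1 stands level with its only measured neighbour. Compound 3 (`CCC(=O)Nc1cc(C(=O)Nc2ccc(N(C)C)cc2)ccc1OC(C)C`) has dimethylamino in place of methoxy on an aromatic carbon, para to a large group: dimethylamino in place of methoxy on an aromatic carbon. For the measured compounds named here, the only measured step, a 1.5-fold lower number from compound 1 to compound 2 (0.19 log units; within the scatter), lies at another place in the molecule, so it bears on this change only indirectly, and no step at this place has been measured. A small shift towards a lower number is therefore expected, the estimated step being a 1.5-fold lower number from compound 1 to compound 3 (0.18 log units; within the scatter). For compound 3 the estimated value is 75000 nM, with an expected range of 25000 nM to 170000 nM.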

Compound 3, half-maximal cytotoxic concentration: 80600 nM
Estimate against measurement, compound 3: 1.1-fold (0.03 log units) below; the measured number falls inside the stated range.
By their numbers in this assay, from the lowest: compounds 2, 3 and 1 (each within the scatter of the next).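

Dimethylamino in place of methoxy, on an aromatic carbon para to a large group, gives a 1.4-fold lower number from compound 1 to compound 3 (0.15 log units; within the scatter) in this assay. Among the compounds shown here, this is the first measured change at this place, and across this one swap the tolerated concentration stays within the scatter. Nothing measured here accounts for this result.

The compounds shown leave open whether a primary amine, a carboxylic acid or a longer alkoxy chain at this place would move the number beyond the scatter. They also leave open whether dimethylamino behaves alike on the ethoxy compound 2.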